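Dimethoxyphenyl in Place of Methylphenyl: an Untested Analogue

The source may report more compounds than this note shows. Statements on the series, on what has been measured and on what is new or still open speak of the compounds shown alone.

Compound 1, `COc1cccc(COc2ccc3cc(C(=O)/C=C/c4ccc(C)cc4)c(=O)oc3c2)c1`: > 50000 nM
Compound 2, `COc1cc(/C=C/C(=O)c2cc3ccc(O)cc3oc2=O)cc(OC)c1OC`: 8800 nM

In a functional assay on MCF7 cells (Homo sapiens) for cytotoxicity, read by MTT assay, with a stated time of 72 h (a lower number here means a stronger inhibitor, a higher number a weaker inhibitor), compound 1 gives > 50000 nM, which is a limit of the assay rather than a number, and marks where compound 1 stands (the limit of > 50000 nM in this assay, at which 1 of the 2 values shown sits). Compound 2 gives 8800 nM in this assay. Compound 3, `COc1cccc(COc2ccc3cc(C(=O)/C=C/c4cccc(OC)c4OC)c(=O)oc3c2)c1`, differs from compound 1 by 2,3-dimethoxyphenyl in place of 4-methylphenyl on a double-bonded chain carbon bound to a double-bonded chain carbon. For the measured compounds named here, no measured pair shows this change, so the step of an at least 1.2-fold lower number from compound 1 to compound 3 (0.09 log units; that floor lies within the scatter) is an expectation only, a modest move toward stronger inhibition that may not exceed the scatter. Compound 3 is expected at 40000 nM, between 10000 nM and 100000 nM, with a real chance that only a limit is reported again.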

Compound 3, half-maximal inhibitory concentration: 35100 nM
Compound 3: middle estimate off by 1.1-fold (0.06 log units), on the high side; low and high end bracket the measured number.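

Replacing 4-methylphenyl with 2,3-dimethoxyphenyl on a double-bonded chain carbon bound to a double-bonded chain carbon gives, in this assay, an at least 1.4-fold lower number from compound 1 to compound 3 (0.15 log units; that floor lies within the scatter). On these data alone, the value of compound 1 is a limit and not a number, so the true size of this step stays unknown: the limit of > 50000 nM in this assay, at which 1 of the 3 values shown sits. Even so, compound 3 gives a measured number at this position, where compound 1 gives only a limit.

As far as these compounds go, whether a phenyl ring carrying an amine or a carboxylic acid in the same place would give a lower number stays open. So does whether one methoxy group would serve as well as two.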